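This account rests on a few compounds, and the source may have more. Where it says the series, first, only, none or still open, it means among the compounds named here.

Measured compounds in an assay on cells for displacement of a labelled ligand from corticotropin-releasing factor receptor 1 (Homo sapiens), with a stated time of 100 min; on this read-out lower numbers stand for stronger inhibition and higher numbers for weaker inhibition:
Compound 1, `CCCN(Cc1c(C(F)(F)F)nc2n(-c3c(C)cc(C)cc3C)c(Cl)cn12)CC1CCC1`: 5.3 nM
Compound 2, `CCN(CCC1CC1)Cc1c(C(F)(F)F)nc2n(-c3c(C)cc(C)cc3C)c(Cl)cn12`: 13 nM
Compound 3, `CCCN(Cc1ccccc1)Cc1c(C(F)(F)F)nc2n(-c3c(C)cc(C)cc3C)c(Cl)cn12`: 170 nM

All three compounds share one core and differ only in the amine carried on a saturated chain carbon bound to an aromatic carbon. Compound 3 gives the highest number of the three: from compound 1 to compound 3 the number rose a 32-fold higher number from compound 1 to compound 3 (1.51 log units; beyond the scatter), and from compound 2 to compound 3 it rose a 13-fold higher number from compound 2 to compound 3 (1.12 log units; beyond the scatter). Between the two compounds that carry only saturated groups on the amine, the step from compound 1 to compound 2 was a 2.5-fold higher number from compound 1 to compound 2 (0.39 log units; beyond the scatter).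

Compound 4, `Cc1cc(C)c(-n2c(Cl)cn3c(CN4CCC(C)CC4)c(C(F)(F)F)nc23)c(C)c1`, has not yet been measured. It differs from compound 3 in one place: 4-methylpiperidin-1-yl in place of benzyl(propyl)amino on a saturated chain carbon bound to an aromatic carbon. The change removes the aromatic ring that distinguishes compound 3 from the other two and returns to an amine carrying only saturated carbon, as in compound 1 and compound 2. The two steps that bear on this are the large rises from compound 1 and from compound 2 to compound 3, so the expectation is a substantial step back downward in this assay, although a cyclic amine of this kind is not directly represented among the measured compounds, which widens the range. Compound 4 is therefore expected to give about 25 nM, within 6 nM to 100 nM, an expected step of a 6.8-fold lower number from compound 3 to compound 4 (0.83 log units; beyond the scatter).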

Compound 4, inhibition constant: 3200 nM
For compound 4 the middle estimate is 130-fold (2.11 log units) below the measured one; measured number outside the range, above it.
By their numbers in this assay, from the lowest: compound 1; then compound 2; then compound 3; then compound 4.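

In this assay, the 4-methylpiperidin-1-yl group does worse than even the benzyl(propyl)amino group (a 19-fold higher number from compound 3 to compound 4 (1.27 log units; beyond the scatter)), so the aromatic ring of compound 3 is not what sets the upper end of the numbers at this position. Carrying only saturated carbon on the amine is also not enough to keep the number low, as the steps from the two amines with separate saturated chains show (a 250-fold higher number from compound 2 to compound 4 (2.39 log units; beyond the scatter); a 600-fold higher number from compound 1 to compound 4 (2.78 log units; beyond the scatter)); among the compounds shown, what sets compound 4 apart is that its amine nitrogen lies inside a ring, whereas in compound 1, compound 2 and compound 3 it carries separate groups. Nothing available here explains the size of these steps.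

With a single cyclic amine, the compounds shown cannot separate the effect of closing the ring from that of the methyl group on it, and plain piperidin-1-yl would begin to tell these apart. Going by these compounds, whether a ring of another kind, such as morpholin-4-yl or the seven-membered azepan-1-yl, behaves like compound 4 also remains open.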